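Chloro in place of hydrogen on compound 3

This account rests on a few compounds, and the source may have more. Where it says the series, first, only, none or still open, it means among the compounds named here.

In a functional assay on DU-145 cells (Homo sapiens) for antiproliferative activity, read by MTT assay, with a stated time of 48 h (on this read-out higher numbers stand for weaker inhibition and lower numbers for stronger inhibition), compound 1 (`COc1ccc(-c2nnc(-c3cn4ccccc4n3)o2)cc1`) gives 12900 nM and compound 2 (`COc1cc(-c2nnc(-c3cn4cccc(C)c4n3)o2)cc(OC)c1OC`) gives 11200 nM on the same read-out. Compound 3 (`Cc1cc(Br)c2nc(-c3nnc(-c4ccccc4)o3)cn2c1`) gives 18900 nM and so lies within the scatter of both, with no order among the three. Compound 4 (`Cc1cc(Br)c2nc(-c3nnc(-c4ccc(Cl)cc4)o3)cn2c1`) has not yet been measured. It differs from compound 3 by chloro in place of hydrogen on an aromatic carbon, para to a large group, so that phenyl becomes 4-chlorophenyl (chloro in place of hydrogen on an aromatic carbon). Within the data shown here, no measured pair differs in one place only, so the data offer no direct guide to this change. Compound 1 at 12900 nM and compound 3 at 18900 nM stand within the scatter of each other although their structures differ in more than one place, so only a small step is expected, towards lower numbers if any. The expected step (a 1.4-fold lower number from compound 3 to compound 4 (0.13 log units; within the scatter)) stays within the scatter. In this assay the estimate for compound 4 is 14000 nM within an expected range from 6000 nM to 30000 nM (both ends estimated).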

Compound 4, half-maximal inhibitory concentration: 46000 nM
Compound 4: the middle estimate sits 3.3-fold (0.52 log units) below what was measured, outside the stated range (above it).
By their numbers in this assay, from the lowest: compounds 2, 1 and 3 (each within the scatter of the next); then compound 4.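

In this assay, chloro in place of hydrogen on an aromatic carbon, para to a large group, gives a 2.4-fold higher number from compound 3 to compound 4 (0.39 log units; beyond the scatter), the first change in a single place among these compounds. It shows that this position does not tolerate every substituent without effect: turning phenyl into 4-chlorophenyl on the core of compound 3 moves the read-out modestly towards weaker inhibition. No measurement shown here gives a reason for this step.

The compounds shown leave open whether this shift is specific to chloro or would also follow from fluoro, a nitrile or an amine on the same carbon. As far as these compounds go, it also remains open whether the same change would produce a similar step on the core of compound 1.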